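Swapping 1H-indol-4-yl for phenyl in compound 1

A few compounds are considered here, and "the series" means these few. Any claim that something is new, unique, unknown or untested is made for them only; others in the source may bear on it.

In a physicochemical assay for solubility (a higher number here means a more soluble compound, a lower number a less soluble compound), compound 1 (`CNC(=O)c1cc(C(=O)NC2CC2)cc2c1OC[C@H]2c1cccc2[nH]ccc12`) gives >= 142 ug/mL, which is a limit and not a number. Compound 2 (`CNC(=O)c1cc(C(=O)N[C@H]2[C@@H]3COC[C@@H]32)cc2c1OC[C@H]2c1cccc2[nH]ccc12`) gives >= 171 ug/mL, also a limit. Compound 3 (`CNC(=O)c1cc(C(=O)N[C@H]2[C@@H]3COC[C@@H]32)cc2c1OC[C@@]2(C)c1ccccc1`), which also carries phenyl, gives >= 147 ug/mL, again a limit. Compound 4 (`CNC(=O)c1cc(C(=O)NC2CC2)cc2c1OC[C@H]2c1ccccc1`) has phenyl in place of 1H-indol-4-yl on a saturated ring carbon. For the measured compounds named here, the one measured step is a step that the two limits leave unreadable from compound 1 to compound 2, and it lies on an amide-type nitrogen, so no measured step gives a size for this change. Only a small shift is therefore expected in this assay, with no clear direction: the expected step is a step that the limit leaves unreadable from compound 1 to compound 4, within the scatter. The estimate for compound 4 is 150 ug/mL, with an expected range of 70 ug/mL to 260 ug/mL.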

Compound 4, solubility: >= 190 ug/mL
Compound 4: only a limit was reported; the forecaster's own chance of this, stated with the estimate: 65%; middle value at least 1.2-fold (0.10 log units) away from the limit.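

Compound 1 and compound 4 are both reported only as limits, so the step between them cannot be read. The compounds shown leave open how large the effect of phenyl in place of 1H-indol-4-yl is in this assay.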